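A few compounds are considered here, and "the series" means these few. Any claim that something is new, unique, unknown or untested is made for them only; others in the source may bear on it.

Values so far, from a functional assay on B16-F10 cells (Mus musculus) for antiproliferative activity, read by MTT assay, with a stated time of 48 h; on this read-out higher numbers stand for weaker inhibition and lower numbers for stronger inhibition

compound 1 `COc1ccc(/C=C/c2cc(OC)cc(OC)c2/C=C/C(=O)c2ccc(C)cc2)cc1` gives 5.3 ug/mL
compound 2 `CCCCCCOc1ccc(C(=O)/C=C/c2c(/C=C/c3ccc(OC)cc3)cc(OC)cc2OC)cc1` gives 10.4 ug/mL

Among the measured compounds shown here, compound 1 stands within the scatter of compound 2, the only other number, so no order can be drawn between them. Compound 3 `COc1ccc(/C=C/c2cc(OC)cc(OC)c2/C=C/C(=O)c2cccc(Cl)c2)cc1` is not yet measured. Its difference from compound 1 is 3-chlorophenyl in place of 4-methylphenyl on a carbonyl carbon. For the measured compounds named here, the one measured step, a 2.0-fold higher number from compound 1 to compound 2 (0.29 log units; within the scatter) with hexyloxy in place of methyl on an aromatic carbon, is the only guide. Going by the values given here, no compound with chlorine has been measured. On that single step, no change beyond the scatter is expected for compound 3 in this assay and the evidence is thin. The expected size is a 1.1-fold higher number from compound 1 to compound 3 (0.05 log units; within the scatter) in this estimate. Compound 3 is estimated at 6 ug/mL (range 2.5 ug/mL to 14 ug/mL).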

Compound 3, half-maximal inhibitory concentration: 3.3 ug/mL
The estimate for compound 3 lay 1.8-fold (0.26 log units) above the measured number; the measured number falls inside the stated range.
By their numbers in this assay, from the lowest: compounds 3, 1 and 2 (each within the scatter of the next, the first and the last beyond it).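

In this assay, 3-chlorophenyl in place of 4-methylphenyl on the carbonyl carbon gives a 1.6-fold lower number from compound 1 to compound 3 (0.21 log units; within the scatter), so this position accepts a chlorine-bearing ring with no change that can be read beyond the scatter. Both groups hold 7 heavy atoms and one six-membered aromatic ring, but the step changes the substituent and its place on the ring together, and the two contributions cannot be separated here. No measurement available bears on what lies behind these numbers.

On these data alone, whether an amine or a carboxylic acid on this ring, or a longer chain in place of the ring, would move the number beyond the scatter remains open. As far as these compounds go, the contribution of the methoxy groups on the shared core also remains open.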